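The compounds below may be only part of what the source reports. "The series", "measured", "known", "first", "only" and "open" are said of these compounds alone.

Measured compounds:
compound 1 `CCC(C(=O)N1CCN(c2cccc(Cl)c2)CC1)N1C(=O)CCC1=O` — 100%
compound 2 `CC(C(=O)N1CCN(c2cccc(Cl)c2)CC1)N1C(=O)CCC1=O` — 75%
compound 3 `CCC(C(=O)N1CCN(c2ccccc2C(F)(F)F)CC1)N1C(=O)CCC1=O` — 0%

In a functional assay on the whole organism (strain Swiss) with Mus musculus as the target, in the maximal electroshock model, with a stated time of 1 h, at a dose of 300 mg/kg by the intraperitoneal route (on this read-out higher numbers stand for a stronger effect at the one dose given and lower numbers for a weaker effect), compound 2 gives 75%, the second highest of the three numbers. For the measured compounds named here, compound 1 sits closer to it, and the one measured step, a number 25 percentage points lower from compound 1 to compound 2 (beyond the scatter), came from the change in which a hydrogen replaces a methyl on the saturated chain carbon two bonds along the chain from the ring nitrogen and the carbonyl carbon. Going by the values given here, compound 3, with a trifluoromethyl instead of chloro on the aromatic ring and the longer chain, gives 0%; no single step links it to compound 2, so its two values can only be set side by side with those of compound 1.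

Compound 4 `CC(C(=O)N1CCN(c2cccc(F)c2)CC1)N1C(=O)CCC1=O` has not yet been measured in this assay. It differs from compound 2 in one place: fluoro in place of chloro on an aromatic carbon. No measured step changes a halogen on the aromatic ring, so nothing shown tells directly how large such a change is. Among the compounds with values here, the one known step concerns the chain, not the ring, and the values of compound 3 show that a different ring substituent can remove the effect entirely, though that change is larger than a swap of one halogen for another. Within the data shown here, with no direct precedent, a small loss or no change beyond the scatter is the most cautious expectation. Compound 4 is therefore estimated at 60%, within 25% to 100%, meaning an expected step of a number 15 percentage points lower from compound 2 to compound 4 (beyond the scatter).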

Compound 4, a percentage reported as activity, at one dose (the size of the read-out at that dose, not a potency): 75%
The estimate for compound 4 lay 15 percentage points below the measured number; the measured number falls inside the stated range.
By their numbers in this assay, from the lowest: compound 3; then compounds 2 and 4 (each within the scatter of the next); then compound 1.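

For the compounds shown here, until now, the only measured step lay in the chain; this is the first to touch the aromatic ring, and in this assay the move from 3-chlorophenyl to 3-fluorophenyl gives no change at the digits printed from compound 2 to compound 4 (within the scatter). At this place on the ring, meta to a large group, the read-out therefore cannot tell these two halogens apart, although a single dose gives the size of the effect at that dose rather than a potency. Nothing measured here explains why the two compounds read alike.

As far as these compounds go, it remains open whether a hydrogen, a methoxy group or a nitrile at the same place would give a similar read-out. From the compounds shown here alone, it is also open whether fluoro would match chloro on the longer chain of compound 1.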